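Swapping the Aromatic Group: From Compound 3 to Compound 4

The source may hold more compounds than are shown below. What is called first, only, known or untested is meant among the compounds shown, and "the series" means these compounds.

compound 1 (`CC1(C)[C@H]2CC[C@]1(C)N(Cc1cn(-c3cccc(C#N)c3)nn1)C(=O)C2`) gives 250 nM
compound 2 (`CC1(C)[C@H]2CC[C@]1(C)N(Cc1cn(-c3cccc(Cl)c3)nn1)C(=O)C2`) gives 510 nM
compound 3 (`COc1ccccc1-n1cc(CN2C(=O)C[C@@H]3CC[C@@]2(C)C3(C)C)nn1`) gives 280 nM

In a functional assay on SGC-7901 cells (Homo sapiens) for inhibition, read by MTT assay, with a stated time of 24 h (on this read-out higher numbers stand for weaker inhibition and lower numbers for stronger inhibition), compound 3 gives 280 nM and cannot be told apart from either of the other two compounds, as both of its steps lie within the scatter (a 1.1-fold higher number from compound 1 to compound 3 (0.05 log units; within the scatter)) and (a 1.8-fold lower number from compound 2 to compound 3 (0.26 log units; within the scatter)). Only the remaining step clears the scatter, and it is modest (a 2.0-fold higher number from compound 1 to compound 2 (0.31 log units; beyond the scatter)).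

Compound 4 (`CC1(C)[C@H]2CC[C@]1(C)N(Cc1cn(-c3ccc(O)cc3)nn1)C(=O)C2`) has 4-hydroxyphenyl in place of 2-methoxyphenyl on an aromatic nitrogen. The measured swaps of this aromatic group are the nearest guide, and all three are small. Among the compounds with values here, the guide is indirect, though, since no measured compound carries a 4-hydroxyphenyl group.

A step of similar size is therefore expected in this assay, most likely none beyond the scatter. A slight lean towards a higher number, meaning weaker inhibition, is only a cautious guess, and nothing measured fixes the direction. The expected step is small (a 1.3-fold higher number from compound 3 to compound 4 (0.10 log units; within the scatter)). For compound 4 the estimated value is 350 nM, with an expected range from 120 nM to 1000 nM.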

Compound 4, half-maximal inhibitory concentration: 330 nM
Compound 4: the middle estimate sits 1.1-fold (0.03 log units) above what was measured, and the stated range covers the measured number.
By their numbers in this assay, from the lowest: compounds 1, 3, 4 and 2 (each within the scatter of the next, the first and the last beyond it).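

In this assay, the 4-hydroxyphenyl group of compound 4 has 1 hydrogen-bond donor where 2-methoxyphenyl has 0, yet this exchange gives a 1.2-fold higher number from compound 3 to compound 4 (0.07 log units; within the scatter) and so leaves no readable effect of adding the donor. The comparisons with the other two aromatic groups read the same way, with a 1.5-fold lower number from compound 2 to compound 4 (0.19 log units; within the scatter) and a 1.3-fold higher number from compound 1 to compound 4 (0.12 log units; within the scatter) both staying within the usual scatter. On the aromatic nitrogen, a phenyl group bearing a hydroxyl can therefore stand in for the cyano, chloro and methoxy versions without a clear separation from any of them, and only a 2.0-fold higher number from compound 1 to compound 2 (0.31 log units; beyond the scatter) still clears the scatter, modestly. Nothing at hand explains why these exchanges change so little.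

The compounds shown leave open whether the hydroxyl would read the same as 2-hydroxyphenyl or 3-hydroxyphenyl, which would separate the effect of the group from that of its place on the ring. They also leave open whether a larger departure on this phenyl ring, such as an amine or a carboxylic acid, would move the number clearly beyond the scatter.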